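Adding Chloro to Compound 2: Expecting Little Movement

The source may report more compounds than this note shows. Statements on the series, on what has been measured and on what is new or still open speak of the compounds shown alone.

Of the compounds shown here, three have been measured in an assay on isolated protein for inhibition of sodium channel protein type 4 subunit alpha (Homo sapiens); a higher number here means that more compound is needed for the effect, a lower number that less compound is needed. Compound 1, `Cc1cccc(C)c1NC(=O)[C@@H]1CCN(Cc2ccccc2)C1`, gives 1700 nM. Compound 2, `Cc1cccc(C)c1OC[C@H](N)c1ccccc1`, gives 3020 nM, and compound 3, `Cc1cccc(C)c1OC[C@@H](N)c1ccccc1`, gives 3020 nM. The two compounds 2 and 3 are mirror-image forms of one another, a point supported by the fact that compounds 2 and 3 differ only in the configuration as drawn, and the step of no change at the digits printed from compound 2 to compound 3 (within the scatter) shows no change between them. Compound 2 therefore sits level with compound 3, and the pair together hold the highest numbers of the three; compound 1 gives a lower number, but that gap stays within the scatter of repeated measurements, so no real order among the three can be claimed.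

The next compound, compound 4, `Cc1cc(Cl)cc(C)c1OC[C@H](N)c1ccccc1`, is not yet measured. It differs from compound 2 by chloro in place of hydrogen on an aromatic carbon: a chloro group replaces a hydrogen atom on an aromatic carbon of a six-membered aromatic ring of carbon only, meta to two methyl groups and para to a large group. Among the compounds with values here, none of the measured steps involves adding a group to that ring; the only measured step concerns configuration alone. There is thus no measured basis for predicting a shift, and compound 4 is expected to land near compound 2, with a wide range. The expected step is a 1.5-fold lower number from compound 2 to compound 4 (0.18 log units; within the scatter). Compound 4 is estimated at 2000 nM, ranging from 600 nM to 7000 nM.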

Compound 4, half-maximal effective concentration: 19500 nM
Compound 4: middle estimate off by 9.8-fold (0.99 log units), on the low side; measured number above the stated range.
By their numbers in this assay, from the lowest: compounds 1, 2 and 3 (each within the scatter of the next); then compound 4.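

In this assay, the place on the six-membered aromatic ring that is meta to two methyl groups and para to a large group proves sensitive to change: chloro in place of hydrogen gives a 6.5-fold higher number from compound 2 to compound 4 (0.81 log units; beyond the scatter), so more compound is needed for the effect. Before this, the only step between measured compounds was a change of configuration that left the number as it was, so this is the first evidence that a single added heavy atom on this ring can move the number beyond the scatter. Nothing among the data shown explains why chloro has this effect here.

One substituent at one place cannot show whether the rise belongs to chloro in particular or would follow from any group there, and a fluoro or methoxy group at the same place would help to separate those two readings. On these data alone, it also remains open whether the mirror-image form of compound 4 would match compound 4, as compound 3 matches compound 2, or whether adding chloro makes configuration matter.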